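A Smaller Group on the Shared Core

The compounds below may be only part of what the source reports. "The series", "measured", "known", "first", "only" and "open" are said of these compounds alone.

Compound 1 `O=c1[nH]c(=O)n([C@H]2C[C@H](O)[C@@H](CO)O2)cc1[N+](=O)[O-]`: 130 nM
Compound 2 `O=c1[nH]c(=O)n([C@H]2C[C@H](O)[C@@H](CO)O2)cc1C#CCCO`: > 200000 nM

In an ADME assay on L1210/0 cells (Mus musculus) for cytotoxicity, with a stated time of 48 h (a lower number here means a stronger inhibitor, a higher number a weaker inhibitor), compound 2 gives > 200000 nM, which is a limit of the assay and not a number. Compound 3 `C[S+]([O-])c1cn([C@H]2C[C@H](O)[C@@H](CO)O2)c(=O)[nH]c1=O` keeps the shared core but carries a new group: a group of 3 heavy atoms (1 carbon, 1 oxygen, 1 sulfur; no ring) in place of a group of 5 heavy atoms (4 carbon, 1 oxygen; no ring), on an aromatic carbon. For the measured compounds named here, one measured step bears on this carbon: an at least 1500-fold higher number from compound 1 to compound 2 (3.18 log units; beyond the scatter), which is large and shows how far a swap here can move the number. A partial move back towards a stronger inhibitor is therefore expected, an at least 6.6-fold lower number from compound 2 to compound 3 (0.82 log units; beyond the scatter). Compound 3 is estimated at 30000 nM, with an expected range of 2000 nM to 200000 nM.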

Compound 3, half-maximal inhibitory concentration: > 200000 nM
Compound 3: a limit, no number (the forecaster's own chance of this, stated with the estimate: 35%); at least 6.6-fold (0.82 log units) between middle value and limit.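

Swapping the nitro group for the group of 3 heavy atoms (1 carbon, 1 oxygen, 1 sulfur) also brings a large loss: an at least 1500-fold higher number from compound 1 to compound 3 (3.18 log units; beyond the scatter). A loss of this size is therefore not tied to the 4-hydroxybut-1-yn-1-yl chain, since it also appears with a group that has the same heavy-atom count as nitro. The step from compound 2 to compound 3 cannot be read, as both values are limits of the assay: the limit of > 200000 nM in this assay, at which 2 of the 3 values shown sit.

As far as these compounds go, how far either compound lies past that limit stays open. So does whether an amine or a bromine atom on this carbon would give a measurable number, as nitro does.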